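Fluorophenyl isomers in an antiproliferative series

The compounds below may be only part of what the source reports. "The series", "measured", "known", "first", "only" and "open" are said of these compounds alone.

- compound 1 `CC1=C(C(=O)c2ccc(F)c(F)c2)C(c2cccc(O)c2)NC(=S)N1C` gives 601 nM; 33700 nM; 736 nM (3 entries)
- compound 2 `CC1=C(C(=O)c2cccc(F)c2)C(c2cccc(O)c2)NC(=S)N1C` gives 2840 nM

For the measured compounds named here, in a functional assay on BXPC-3 cells (Homo sapiens) for antiproliferative activity, read by resazurin assay, with a stated time of 72 h (a lower number here means that less compound is needed, a higher number that more compound is needed for the effect), compound 2 reads 2840 nM as its only number, and one further entry carries no single number. The entries for compound 1 spread widely (the several entries of compound 1 in this assay, 601 nM; 33700 nM; 736 nM (3 entries)), so they offer only a loose reference. Compound 3 `CC1=C(C(=O)c2ccc(F)cc2)C(c2cccc(O)c2)NC(=S)N1C` is still unmeasured and carries 4-fluorophenyl in place of 3-fluorophenyl on a carbonyl carbon. Going by the values given here, no measured step in this assay covers this change, so the expected shift stays within the scatter, leaning slightly toward less compound needed (a 1.6-fold lower number from compound 2 to compound 3 (0.20 log units; within the scatter)). The estimate for compound 3 is 1800 nM (expected range 500 nM to 7000 nM).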

Compound 3, half-maximal effective concentration: 2160 nM
Compound 3: middle estimate off by 1.2-fold (0.08 log units), on the low side; the measured number falls inside the stated range.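

In this assay, for the compounds shown here, 4-fluorophenyl in place of 3-fluorophenyl on a carbonyl carbon gives a 1.3-fold lower number from compound 2 to compound 3 (0.12 log units; within the scatter), the first readable step at this position. The two fluorophenyl isomers therefore cannot be told apart in this read-out, so the location of the fluorine shows no effect beyond the scatter here. Compound 1 gives no firm reference for either isomer: the several entries of compound 1 in this assay, 601 nM; 33700 nM; 736 nM (3 entries)

As far as these compounds go, it remains open whether a phenyl carrying methoxy or an amine instead of fluorine would separate from these isomers. Unsubstituted phenyl at this position is equally open.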